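Three Compounds at the Limit, and a Fourth to Come

A few compounds are considered here, and "the series" means these few. Any claim that something is new, unique, unknown or untested is made for them only; others in the source may bear on it.

Compound 1 `N=C(S)CCCCn1nc(-c2ccccc2)ccc1=O` carries a saturated chain that ends in a sulfur-bearing group, attached to a shared core. Compound 2 `N=C(S)CCn1nc(-c2ccc(Cl)cc2)ccc1=O` and compound 3 `N=C(S)CCn1ncccc1=O` are built on the same core with shorter chains and different decoration of the ring system.

In a functional assay on the whole organism (stomach) with Rattus norvegicus as the target (on this read-out higher numbers stand for an effect only at larger amounts of compound and lower numbers for an effect already at smaller amounts), compound 1 gives > 100 mg/kg, which is a limit of the assay rather than a number. Compound 2 gives > 100 mg/kg in this assay, again only a limit. Compound 3 gives > 100 mg/kg, also a limit. Going by the values given here, compound 1 thus stands where every measured value stands, namely at the limit of > 100 mg/kg in this assay, at which 3 of the 3 values shown sit; no compound here is separated from another by a measured step.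

Compound 4 `C/N=C(/S)CCCCCn1nc(-c2ccccc2)ccc1=O` differs from compound 1 by a group of 5 heavy atoms (3 carbon, 1 nitrogen, 1 sulfur; no ring) in place of a group of 3 heavy atoms (1 carbon, 1 nitrogen, 1 sulfur; no ring), on a saturated chain carbon, four bonds along the chain from an aromatic nitrogen. Among the compounds with values here, no step between two measured compounds exists, so nothing in the numbers tells how large an effect this change brings. Because the limit of > 100 mg/kg in this assay, at which 3 of the 3 values shown sit, holds for all three measured compounds, the step expected from compound 1 to compound 4 in this assay, a step that the limit leaves unreadable from compound 1 to compound 4, is none beyond the scatter. Compound 4 is therefore expected near 150 mg/kg, in a range from 50 mg/kg to 500 mg/kg, most likely reported again as a limit.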

Compound 4, dose for half-maximal effect: 25.2 mg/kg
Beside the measured number, compound 4's estimate is 6.0-fold (0.77 log units) above it; the measured number lies below the stated range.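

In this assay, the swap on a saturated chain carbon, four bonds along the chain from an aromatic nitrogen, gives an at least 3.9-fold lower number from compound 1 to compound 4 (0.59 log units; beyond the scatter). For compound 1, the value of > 100 mg/kg is a limit and not a number, so the true size of this step cannot be read and only its smallest possible size is known. The step shows that this position can take the group of 5 heavy atoms, with 1 hydrogen-bond donor, in place of the group of 3 heavy atoms, with 2 hydrogen-bond donors, and give a measurable effect on the shared core, something the earlier compounds could not show, since they all sat at one limit: the limit of > 100 mg/kg in this assay, at which 3 of the 4 values shown sit.

The entering group differs from the leaving one in more than one respect, so this single step cannot say which difference matters, or whether the phenyl-bearing core of compound 4 is needed at all. As far as these compounds go, how a still longer chain, an amine or a carboxylic acid at this position would behave also stays open.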